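The source may hold more compounds than are shown below. What is called first, only, known or untested is meant among the compounds shown, and "the series" means these compounds.

Within the data shown here, compound 1 `C#CCN(Cc1ccc2nc(C)nc(O)c2c1)c1ccc(C(=O)N[C@@H](CCC(=O)O)C(=O)N2CCCC2C(=O)O)cc1` is one of three compounds measured in an assay on L1210 cells for inhibition of Thymidylate synthase (Mus musculus); on this read-out higher numbers stand for weaker inhibition and lower numbers for stronger inhibition. Compound 1 gives 35 nM, the highest of the three numbers. Compound 2 `C#CCN(Cc1ccc2nc(C)nc(O)c2c1)c1ccc(C(=O)N[C@@H](CC(C)(C)C(=O)O)C(=O)N[C@@H](CCC(=O)O)C(=O)O)cc1` gives 18 nM, a gap from compound 1 that lies within the scatter of this kind of measurement. Compound 3 `Cc1nc(O)c2cc(CN(C)c3ccc(C(=O)N[C@@H](CCC(=O)O)C(=O)N(C)[C@@H](CCC(=O)O)C(=O)O)c(F)c3)c(C)cc2n1` gives 3 nM, a gap from compound 1 that lies beyond the scatter. Compound 4 `C#CCN(Cc1ccc2nc(C)nc(O)c2c1)c1ccc(C(=O)N[C@@H](CCC(=O)O)C(=O)N(C)[C@@H](CCC(=O)O)C(=O)O)cc1` differs from compound 1 in one place: (1,3-dicarboxypropyl)(methyl)amino in place of 2-carboxypyrrolidin-1-yl on a carbonyl carbon. The (1,3-dicarboxypropyl)(methyl)amino group also appears in compound 3, which differs from compound 1 elsewhere as well. A moderate step toward stronger inhibition is expected, a 2.3-fold lower number from compound 1 to compound 4 (0.37 log units; beyond the scatter), partly because compound 3 carrying this group gives 3 nM. Compound 4 is estimated at 15 nM, within a range from 5 nM to 50 nM.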

Compound 4, inhibition constant: 11 nM
Beside the measured number, compound 4's estimate is 1.4-fold (0.13 log units) above it; measured number inside the range.
By their numbers in this assay, from the lowest: compound 3; then compounds 4, 2 and 1 (each within the scatter of the next, the first and the last beyond it).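

In this assay, the open-chain (1,3-dicarboxypropyl)(methyl)amino in place of 2-carboxypyrrolidin-1-yl on a carbonyl carbon gives a 3.2-fold lower number from compound 1 to compound 4 (0.50 log units; beyond the scatter), a modest step. Among these compounds, this is the first comparison here in which only this group changes, so the group alone moves the number, apart from the other differences in compound 3. No measurement shown explains the step.

Whether the extra carboxylic acid, the methyl on nitrogen or the loss of the ring accounts for it stays open. Also open, on these data alone, is what an amide hydrogen in place of that methyl, or a longer chain ending in a carboxylic acid, would do.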